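Removing a sugar from two glycosides: cytotoxicity in cells

The compounds below may be only part of what the source reports. "The series", "measured", "known", "first", "only" and "open" are said of these compounds alone.

Measured compounds:
- Compound 1 `CC(=O)O[C@@]1(C)CC[C@H](O[C@@H]2O[C@H](CO)[C@H](O)[C@H](O)[C@H]2O)C(C)(C)[C@@H]1CC/C(C)=C/C[C@@H](O)/C=C(\C)[C@@H](O)C[C@@H]1C(C)=CCC(=O)C1(C)C`: in a functional assay on K562 cells (Homo sapiens) for cytotoxicity, read by spectrophotometry (a higher number here means a weaker inhibitor, a lower number a stronger inhibitor), compound 1 reaches only the limit > 100000 nM, not a number.
- Compound 2 `CC(=O)O[C@@]1(C)CC[C@H](O)C(C)(C)[C@@H]1CC/C(C)=C/C[C@@H](O)/C=C(\C)[C@@H](O)C[C@@H]1C(C)=CCC(=O)C1(C)C`: in this assay compound 2 gives 14800 nM.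
- Compound 3 `CC(=O)O[C@@H](C[C@H]1C(C)(C)C(=O)C=C[C@]1(C)O)/C(C)=C/[C@H](O)C/C=C(\C)CC[C@H]1C(C)(C)[C@@H](O[C@@H]2O[C@H](CO)[C@H](O)[C@H](O)[C@H]2O)CC[C@]1(C)OC(C)=O`: in this assay compound 3 likewise reaches only the limit > 100000 nM.

Compound 2 differs from compound 1 by hydrogen in place of 3,4,5-trihydroxy-6-(hydroxymethyl)oxan-2-yl on an oxygen on a saturated carbon. That change gave an at least 6.7-fold lower number from compound 1 to compound 2 (0.82 log units; beyond the scatter); its size is known only as a bound because of the limit of > 100000 nM in this assay, at which 2 of the 3 values shown sit. How the core of compound 3 differs from that of compound 1 is not broken down here.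

Compound 4 `CC(=O)O[C@@H](C[C@H]1C(C)(C)C(=O)C=C[C@]1(C)O)/C(C)=C/[C@H](O)C/C=C(\C)CC[C@H]1C(C)(C)[C@@H](O)CC[C@]1(C)OC(C)=O`, not yet measured, differs from compound 3 by hydrogen in place of 3,4,5-trihydroxy-6-(hydroxymethyl)oxan-2-yl on an oxygen on a saturated carbon, the same change as that from compound 1 to compound 2, at the same kind of place. The account expects a similar step, an at least 4.0-fold lower number from compound 3 to compound 4 (0.60 log units; beyond the scatter), resting on an at least 6.7-fold lower number from compound 1 to compound 2 (0.82 log units; beyond the scatter); since compound 3 sits at a limit, the true size of the expected step is itself uncertain. For compound 4 the estimate in this assay is 25000 nM, expected to fall between 8000 nM and 100000 nM.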

Compound 4, half-maximal inhibitory concentration: 27500 nM
The estimate for compound 4 lay 1.1-fold (0.04 log units) below the measured number; measured number inside the range.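

In this assay the loss of the 3,4,5-trihydroxy-6-(hydroxymethyl)oxan-2-yl group, leaving a hydroxy on the saturated ring carbon, gave an at least 3.6-fold lower number from compound 3 to compound 4 (0.56 log units; beyond the scatter) and so went the same way on this second core as on the first. Set side by side, the two steps read as follows: the same change on two cores in this assay, an at least 6.7-fold lower number (0.82 log units; beyond the scatter) from compound 1 to compound 2 and an at least 3.6-fold lower number (0.56 log units; beyond the scatter) from compound 3 to compound 4; the limit leaves it open whether they differ. This shows that the change carried over in direction on these two cores, but it does not show that it is worth the same amount on each, or how large either step truly is, since both glycosides stand at a limit rather than at a number: the limit of > 100000 nM in this assay, at which 2 of the 4 values shown sit.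

The compounds shown leave open what a methyl ether or an acetate on that same oxygen would do in this assay in place of the sugar or the free hydroxy. They also leave open how a glycoside bearing a disaccharide or an amino sugar would compare with the hydroxy compounds on either core.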